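Penam-derived ylidenes: cytotoxicity in A-375 cells

The source may report more compounds than this note shows. Statements on the series, on what has been measured and on what is new or still open speak of the compounds shown alone.

Measured compounds:
compound 1 `CC1(C)[C@H](C(=O)OC(c2ccccc2)c2ccccc2)N2C(=O)/C(=C/C(=O)c3ccccc3)[C@H]2S1(=O)=O`: 17500 nM
compound 2 `CCOC(=O)/C=C1/C(=O)N2[C@@H]1SC(C)(C)[C@@H]2C(=O)OC(c1ccccc1)c1ccccc1`: 7000 nM
compound 3 `CC1(C)S[C@@H]2/C(=C\C(=O)OC(c3ccccc3)c3ccccc3)C(=O)N2[C@H]1C(=O)OC(c1ccccc1)c1ccccc1`: 9100 nM

In a functional assay on A-375 cells (Homo sapiens) for cytotoxicity, read by MTT assay, with a stated time of 48 h (a lower number here means a stronger inhibitor, a higher number a weaker inhibitor), compound 2 gives 7000 nM, the lowest of the three numbers. Compound 3 stands closest, and in this assay compound 3 gives 9100 nM, a gap within the usual scatter, so no order between compound 2 and compound 3 can be claimed. Compound 1, which carries a sulfone on the shared core and a benzoyl group on the exocyclic double bond, lies further away; in this assay compound 1 gives 17500 nM, a gap beyond the scatter.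

Compound 4 `CC1(C)S[C@@H]2/C(=C\C(=O)c3ccc(Cl)cc3)C(=O)N2[C@H]1C(=O)OC(c1ccccc1)c1ccccc1` is not yet measured. It differs from compound 2 in one place: 4-chlorophenyl in place of ethoxy on a carbonyl carbon. Going by the values given here, no pair of measured compounds shows this change directly. The only aryl ketone measured, compound 1, also carries the sulfone, so its higher number cannot be assigned to the ketone alone. A modest move toward a weaker inhibitor is expected; the step of a 1.6-fold higher number from compound 2 to compound 4 (0.20 log units; within the scatter) is an estimate. For compound 4 the expected value in this assay is 11000 nM, within a range from 4500 nM to 28000 nM.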

Compound 4, half-maximal inhibitory concentration: 48600 nM
Estimate against measurement, compound 4: 4.4-fold (0.65 log units) below; measured number above the stated range.
By their numbers in this assay, from the lowest: compounds 2, 3 and 1 (each within the scatter of the next, the first and the last beyond it); then compound 4.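

Read in this assay, 4-chlorophenyl in place of ethoxy on a carbonyl carbon gives a 6.9-fold higher number from compound 2 to compound 4 (0.84 log units; beyond the scatter) and so sets this position apart from the two esters, compound 2 and compound 3, which stood within the scatter of each other. Compound 4 carries no sulfone, so an aryl ketone here reaches a higher number without that group, which compound 1 could not show. No measurement shown gives a reason for this step.

Still open, as far as these compounds go, is whether the chlorine or the phenyl ring itself carries the step, and what the sulfone does alone with the same group on the carbonyl carbon. Also open, from the compounds shown here alone, is how an amine or a carboxylic acid at this carbonyl carbon would read in this assay on the shared core.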